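The source may hold more compounds than are shown below. What is called first, only, known or untested is meant among the compounds shown, and "the series" means these compounds.

Series notes. For the measured compounds named here, compound 3 `N=C(NCCCc1c[nH]cn1)NCCC(c1cccc(F)c1)c1ccccn1` gives 7.79 in a functional assay on muscle tissue for agonist activity at histamine H2 receptor (Cavia porcellus) (on this read-out lower numbers stand for lower potency and higher numbers for higher potency (the scale is a negative logarithm)), the highest of the three numbers measured so far. Compound 1 `N=C(NCCCc1c[nH]cn1)NCCC(c1ccccc1)c1ccccn1` gives 7.37 in this assay, and compound 2 `N=C(NCCCc1c[nH]cn1)NCCC(c1ccc(C(F)(F)F)cc1)c1ccccn1` gives 7.23. The measured steps run a number 0.14 log units lower from compound 1 to compound 2 (within the scatter), a number 0.42 log units higher from compound 1 to compound 3 (beyond the scatter) and a number 0.56 log units higher from compound 2 to compound 3 (beyond the scatter), so compound 3 is set apart from both others beyond the scatter.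

Compound 4 `N=C(NCCCc1c[nH]cn1)NCCC(c1cc(F)cc(F)c1)c1ccccn1` differs from compound 3 by fluoro in place of hydrogen on an aromatic carbon, that is, 3-fluorophenyl to 3,5-difluorophenyl, with the entering fluoro placed meta to a fluoro group and meta to a large group. Going by the values given here, the one measured step of the same kind, a number 0.42 log units higher from compound 1 to compound 3 (beyond the scatter), was a modest gain; the other change on the same group, a number 0.14 log units lower from compound 1 to compound 2 (within the scatter), stayed within the scatter. Among the compounds with values here, a second fluoro on this group has no measured precedent. The expected step in this assay is a number 0.06 log units higher from compound 3 to compound 4 (within the scatter), small and possibly within the scatter. Compound 4 is accordingly estimated at 7.85, with a range from 7.3 to 8.4.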

Compound 4, negative logarithm of the half-maximal effective concentration: 7.91
For compound 4 the middle estimate is 0.06 log units below the measured one; low and high end bracket the measured number.
By their numbers in this assay, from the lowest: compounds 2 and 1 (each within the scatter of the next); then compounds 3 and 4 (each within the scatter of the next).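

In this assay, a second fluoro on this group gives a step that cannot be told from the scatter, with a number 0.12 log units higher from compound 3 to compound 4 (within the scatter), so a fluoro entering meta to a fluoro group is tolerated without a clear further gain. The 3,5-difluorophenyl group stays clear of the other two groups, with a number 0.54 log units higher from compound 1 to compound 4 (beyond the scatter) and a number 0.68 log units higher from compound 2 to compound 4 (beyond the scatter), so the separation first seen with 3-fluorophenyl is kept. No outside evidence bears on this result.

Open, going by these compounds, is whether the separation belongs to fluoro itself or would also appear with chloro, methoxy or nitrile in the same places on this ring. Also open, on these data alone, is whether the same fluoro pattern would hold on the pyridine-free analogue carrying a second phenyl group in place of the other aromatic group.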